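The compounds below may be only part of what the source reports. "The series", "measured", "known", "first", "only" and "open" are said of these compounds alone.

Measured compounds:
- compound 1, `Fc1ccc(C2=NN(C3=NC(c4ccccc4)CS3)C(c3cccc4ccccc34)C2)cc1`, 23200 nM
- compound 2, `Fc1ccc(C2=NN(C3=NC(c4ccccc4)CS3)C(c3ccc4ccccc4c3)C2)cc1`, 26500 nM
- compound 3, `O=C1CSC(N2N=C(c3ccc(F)cc3)CC2c2cccc3ccccc23)=N1`, 19500 nM

In a functional assay on HepG2 cells (Homo sapiens) for inhibition, read by CCK-8 assay, with a stated time of 48 h (a higher number here means a weaker inhibitor, a lower number a stronger inhibitor), compound 1 gives the second highest of the three numbers. Its nearest neighbour is compound 2, with a 1.1-fold higher number from compound 1 to compound 2 (0.06 log units; within the scatter); the furthest is compound 3, with a 1.2-fold lower number from compound 1 to compound 3 (0.08 log units; within the scatter). All three numbers therefore sit together within the usual scatter, and no order among them can be read.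

The next compound is compound 4, `Clc1ccc(C2=NN(C3=NC(c4ccccc4)CS3)C(c3cccc4ccccc34)C2)cc1`. Relative to compound 1 the change is chloro in place of fluoro on an aromatic carbon. Neither measured step touches this part of the shared core: the step from compound 1 to compound 2 and the step from compound 1 to compound 3 each alter a different group, and the 4-fluorophenyl group is kept unchanged in compound 1, compound 2 and compound 3. Going by the values given here, there is thus no measured step that bears on a chloro-for-fluoro exchange at this place, and nothing points to a move in either direction.

For compound 4 the step in this assay is expected to be a 1.1-fold lower number from compound 1 to compound 4 (0.02 log units; within the scatter), that is, nothing beyond the scatter. Compound 4 is accordingly estimated at 22000 nM, with a range from 8000 nM to 60000 nM.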

Compound 4, half-maximal inhibitory concentration: 18700 nM
Compound 4: the middle estimate sits 1.2-fold (0.07 log units) above what was measured; measured number inside the range.
By their numbers in this assay, from the lowest: compounds 4, 3, 1 and 2 (each within the scatter of the next).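

Held fixed until now, the 4-fluorophenyl group is varied here for the first time, and in this assay the change to 4-chlorophenyl gives a 1.2-fold lower number from compound 1 to compound 4 (0.09 log units; within the scatter). This aromatic carbon therefore accepts chloro in place of fluoro with no readable shift in the number, and the series now holds single-place changes at three places, none of which gives a step beyond the scatter. Nothing measured on these compounds bears on the reason for this result.

On these data alone, whether a different kind of group at this place, such as an amine, a methoxy group or a carboxylic acid, would move the number beyond the scatter remains open, as does the outcome of having no substituent on this ring at all. With each value within the scatter of the next, the compounds shown do not tell which part of the structure, if any, governs the number in this assay or whether any change to the shared core can bring a clear step in either direction.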